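Lengthening a hydroxylated side chain on a shared core

The compounds below may be only part of what the source reports. "The series", "measured", "known", "first", "only" and "open" are said of these compounds alone.

Compound 2 `CC1=C(SCCCCO)C(=O)c2ccccc2C1=O` carries a hydroxylated chain on a sulfur attached to the shared core. In a functional assay on MES-SA cells (Homo sapiens) for inhibition (on this read-out higher numbers stand for weaker inhibition and lower numbers for stronger inhibition), compound 2 gives only a limit of the assay, > 10000 nM. Compound 1 `CC1=C(SCCCO)C(=O)c2ccccc2C1=O` also reaches only a limit, > 10000 nM. The step that the two limits leave unreadable from compound 1 to compound 2 is therefore unreadable, since both values sit at the limit of > 10000 nM in this assay, at which 2 of the 2 values shown sit. Compound 3 `CC1=C(SCCCCCCO)C(=O)c2ccccc2C1=O` differs from compound 2 by 2-hydroxyethyl in place of hydroxy on a saturated chain carbon, four bonds along the chain from a sulfur. No readable step bears on this change, so no shift beyond the scatter is expected in this assay. The expected step that the limit leaves unreadable from compound 2 to compound 3 is small. Compound 3 is estimated at 15000 nM, within a range from 4000 nM to 50000 nM, most likely again reported only as a limit.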

Compound 3, half-maximal inhibitory concentration: > 10000 nM
Compound 3: only a limit was reported; the forecaster's own chance of this, stated with the estimate: 80%; the middle value lies beyond the limit too.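

Compound 1, compound 2 and compound 3 all reach only a limit in this assay, so no step among them can be read: the limit of > 10000 nM in this assay, at which 3 of the 3 values shown sit.

The compounds shown leave open whether the length of the hydroxylated chain affects inhibition at all.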